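A few compounds are considered here, and "the series" means these few. Any claim that something is new, unique, unknown or untested is made for them only; others in the source may bear on it.

Measured compounds:
compound 1 `COc1cc(O)ccc1N1CCN(CC(O)COc2ccc(O)c3ccccc23)CC1`: > 50000 nM
compound 2 `Oc1ccc(N2CCN(CC(O)COc3ccc(O)c4ccccc34)CC2)c(O)c1`: 40400 nM

In an ADME assay on HEK293 cells (Homo sapiens) for cytotoxicity, read by MTT assay, with a stated time of 48 h (a higher number here means a weaker inhibitor, a lower number a stronger inhibitor), compound 1 gives only a limit, > 50000 nM. Compound 2 gives 40400 nM in this assay. Among the measured compounds shown here, the one measured step, an at least 1.2-fold lower number from compound 1 to compound 2 (0.09 log units; that floor lies within the scatter), is hydrogen in place of methyl on an oxygen on an aromatic ring, and it rests on one value that is a limit (the limit of > 50000 nM in this assay, at which 1 of the 2 values shown sits). Compound 2 thus stands as the only number shown, beside one limit.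

Compound 3 `COc1ccccc1N1CCN(CC(O)COc2ccc(O)c3ccccc23)CC1` carries 2-methoxyphenyl in place of 2,4-dihydroxyphenyl on an amine nitrogen in a ring. For the measured compounds named here, only the step from compound 1 to compound 2 bears on this change, and it was no larger than the scatter. Compound 3 is therefore expected to show no step beyond the scatter in this assay, a 1.2-fold higher number from compound 2 to compound 3 (0.09 log units; within the scatter), with a fair chance that only a limit is reported. The estimate for compound 3 is 50000 nM, between 25000 nM and 100000 nM.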

Compound 3, half-maximal inhibitory concentration: > 50000 nM
Compound 3: a limit, no number; the forecaster's own chance of this, stated with the estimate: 50%; the middle value sits exactly at the limit.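

In this assay compound 3 gives only a limit, > 50000 nM. Among the compounds shown here, on the amine nitrogen in a ring, 2-methoxyphenyl in place of 2,4-dihydroxyphenyl gives an at least 1.2-fold higher number from compound 2 to compound 3 (0.09 log units; that floor lies within the scatter), so this larger change at the position shows no step that can be placed beyond the scatter, though a larger one is not ruled out. The step from compound 1 to compound 3 cannot be read, because both values are limits: the limit of > 50000 nM in this assay, at which 2 of the 3 values shown sit.

The compounds shown leave open how far compound 1 and compound 3 lie past that limit, and so whether either hydroxy group counts on its own. They also leave open whether an amine or a carboxylic acid in place of the methoxy group, or a longer chain on the ring nitrogen, would move the number in this assay beyond the scatter.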